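Chalcone triazole series: cytotoxicity notes before compound 3

The compounds below may be only part of what the source reports. "The series", "measured", "known", "first", "only" and "open" are said of these compounds alone.

Compound 1, `O=C(/C=C/c1ccc(Br)cc1)c1ccc(OCc2cn(Cc3ccc(Br)cc3)nn2)cc1O`: "not determined" (no result reported)
Compound 2, `CCCCCCn1cc(COc2ccc(C(=O)/C=C/c3ccc(Br)cc3)c(O)c2)nn1`: > 100000 nM

Two members of the series have entered an ADME assay on cells (Macrophage) for cytotoxicity, read by resazurin assay, with a stated time of 48 h; on this read-out lower numbers stand for higher toxicity in this test and higher numbers for lower toxicity in this test. For compound 1 the result in this assay is "not determined" (no result reported), so compound 1 has no number to stand on. Within the data shown here, the one further value in the set is a limit rather than a number. In this assay compound 2 gives > 100000 nM, a limit of the assay (the limit of > 100000 nM in this assay, at which 1 of the 2 values shown sits). Among the measured compounds shown here, no two measured compounds differ in a single place, so no measured step exists.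

Compound 3, `O=C(/C=C/c1ccccc1)c1ccc(OCc2cn(Cc3ccc(Br)cc3)nn2)cc1O`, is the next to go into this assay. It differs from compound 1 by hydrogen in place of bromo on an aromatic carbon. For the measured compounds named here, with no measured step, the step from compound 1 to compound 3 in this assay is expected to be none beyond the scatter, in either direction. Compound 3 is expected to read about 100000 nM, between 30000 nM and 300000 nM, quite possibly again as a limit only.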

Compound 3, half-maximal cytotoxic concentration: 71700 nM
Beside the measured number, compound 3's estimate is 1.4-fold (0.14 log units) above it; the range from low to high includes it.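

Among these compounds, compound 1 has no number in this assay, and no step to compound 3 can be read there. The compounds shown leave open how 4-bromophenyl to phenyl alone shifts this read-out, and the set still holds a limit: the limit of > 100000 nM in this assay, at which 1 of the 3 values shown sits.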